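The source may report more compounds than this note shows. Statements on the series, on what has been measured and on what is new or still open speak of the compounds shown alone.

The account opens with compound 1 `CC(C)(C(=O)O)N1CCCN(c2ccc(F)c(C(F)(F)F)c2)C1=O` and compound 2 `O=C(O)CNC(=O)Nc1ccc(F)c(C(F)(F)F)c1`, which share the same core. In a physicochemical assay for solubility, read by nephelometry, measured as kinetic solubility, at pH 2, tested at 10 mg/mL (on this read-out higher numbers stand for higher solubility and lower numbers for lower solubility), compound 1 reaches > 100 ug/mL, which is a limit of the assay rather than a number. In this assay compound 2 likewise reaches > 100 ug/mL, again a limit of the assay and not a number. Compound 2 therefore stands exactly where the other shown value stands, namely at the limit of > 100 ug/mL in this assay, at which 2 of the 2 values shown sit, so no ordering between the two can be drawn from these figures.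

Against this background stands compound 3 `CC(C)(NC(=O)Nc1ccc(F)c(C(F)(F)F)c1)C(N)=O`, not yet measured. It differs from compound 2 by a single change: 1-carbamoyl-1-methylethyl in place of carboxymethyl on an amide-type nitrogen. Within the data shown here, no measured pair here carries the same change, so the step in this assay can only be estimated, and it is expected to be small, within the scatter or at most a slight decrease: an at least 1.1-fold lower number from compound 2 to compound 3 (0.04 log units; that floor lies within the scatter). Compound 3 is accordingly expected to give about 90 ug/mL in this assay, with a range from 35 ug/mL to 150 ug/mL. There remains a fair chance that the assay again reports only a limit for compound 3, as it did for compound 2.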

Compound 3, solubility: 50 ug/mL
For compound 3 the middle estimate is 1.8-fold (0.26 log units) above the measured one; the range from low to high includes it.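

Among these compounds, with compound 3, this assay gives a number rather than a limit for the first time, as compound 3 reads 50 ug/mL. Among the compounds shown here, putting 1-carbamoyl-1-methylethyl in place of carboxymethyl on the amide-type nitrogen comes out as an at least 2.0-fold lower number from compound 2 to compound 3 (0.30 log units; that floor lies within the scatter), and only this floor of the step can be read, so the true step may be larger. The amide-type nitrogen is thus the first place in the series where a single change moves the read-out off the limit shared by the earlier compounds: the limit of > 100 ug/mL in this assay, at which 2 of the 3 values shown sit.

The compounds shown leave open how much of this step belongs to the carbamoyl end of the new group and how much to its methyl groups. A carbamoylmethyl group or a 1-carboxy-1-methylethyl group on the same nitrogen would separate these two parts, and a read-out of compound 2 as a number instead of a limit would fix the full size of the step.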